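The compounds below may be only part of what the source reports. "The series", "measured", "known", "first", "only" and "open" are said of these compounds alone.

Measured in a toxicity assay on GES1 cells (Homo sapiens) for inhibition, read by MTT assay, with a stated time of 72 h; a lower number here means a stronger inhibitor, a higher number a weaker inhibitor:

- compound 1, `Cc1cc(N2CC[C@@H](C)[C@@H](N(C)c3ncnc4[nH]ccc34)C2)n2ncnc2n1`: 57900 nM
- compound 2, `Cc1cc(N2CC[C@@H](C)[C@@H](N(C)c3ncnc4[nH]ccc34)C2)n2nc(SCC3CCCCC3)nc2n1`: 98200 nM
- compound 3, `Cc1cc(N2CC[C@@H](C)[C@@H](N(C)c3ncnc4[nH]ccc34)C2)n2nc(SCCCc3ccccc3)nc2n1`: > 100000 nM, which is a limit of this assay and not a number

Compound 1 holds the lowest of the two numbers given in this assay. The nearest is compound 2, with a 1.7-fold higher number from compound 1 to compound 2 (0.23 log units; within the scatter). The third member, compound 3, stops at the limit, as noted in the limit of > 100000 nM in this assay, at which 1 of the 3 values shown sits.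

The next compound, compound 4, is `Cc1cc(N2CC[C@@H](C)[C@@H](N(C)c3ncnc4[nH]ccc34)C2)n2nc(SCc3ccc(F)cc3)nc2n1`. Set against compound 1 the change is (4-fluorobenzyl)sulfanyl in place of hydrogen on an aromatic carbon.

For the measured compounds named here, two measured steps bear on this: both start from compound 1 and attach a sulfanyl-linked chain at the same aromatic carbon. They gave a 1.7-fold higher number from compound 1 to compound 2 (0.23 log units; within the scatter) and an at least 1.7-fold higher number from compound 1 to compound 3 (0.23 log units; that floor lies within the scatter). Between the two chains, an at least 1.0-fold higher number from compound 2 to compound 3 (0.00 log units; that floor lies within the scatter) adds nothing beyond scatter either. Every substituent of this kind so far has left the number where it was or nudged it upward, and compound 4 carries a chain of comparable bulk to that of compound 2, so in this assay a move of the same small size, toward a higher number, is expected, but not one that clears the scatter.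

Compound 4 is therefore expected at 90000 nM, within 45000 nM to 160000 nM. That estimate means a 1.6-fold higher number from compound 1 to compound 4 (0.19 log units; within the scatter), and there is a fair chance that this assay will report only its limit for compound 4.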

Compound 4, half-maximal inhibitory concentration: 12300 nM
Compound 4: the middle estimate sits 7.3-fold (0.86 log units) above what was measured, outside the stated range (below it).
By their numbers in this assay, from the lowest: compound 4; then compounds 1 and 2 (each within the scatter of the next). At a limit, above all of these: compound 3.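

In this assay, for the compounds shown here, the aromatic carbon between two ring nitrogen atoms turns out not to be indifferent to substitution: (4-fluorobenzyl)sulfanyl gives a 4.7-fold lower number from compound 1 to compound 4 (0.67 log units; beyond the scatter), the only step from the unsubstituted core at this position printed as beyond the scatter, and its direction is toward a lower number. The sulfanyl link alone therefore does not set the outcome, since what sits on the saturated chain carbon bound to the sulfur matters: 4-fluorophenyl in place of cyclohexyl gives an 8.0-fold lower number from compound 2 to compound 4 (0.90 log units; beyond the scatter), and 4-fluorophenyl in place of phenethyl gives an at least 8.1-fold lower number from compound 3 to compound 4 (0.91 log units; beyond the scatter). The entry for compound 3 is a limit and not a number, so the last of these steps is only a floor: the limit of > 100000 nM in this assay, at which 1 of the 4 values shown sits.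

The compounds shown do not divide the step between the fluorine and the rest of the chain, and a plain benzylsulfanyl group or a 4-chlorobenzylsulfanyl group would bear on that. Also open, as far as these compounds go, is whether a chain ending in an amine or a carboxylic acid at this position would move the number in this assay in either direction.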